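The source may hold more compounds than are shown below. What is called first, only, known or untested is meant among the compounds shown, and "the series" means these compounds.

In a functional assay for inhibition, with Homo sapiens as the target (a higher number here means a weaker inhibitor, a lower number a stronger inhibitor), compound 1 (`CCOC(=O)c1cccc(Nc2nccc(-c3ccccn3)n2)c1`) gives 3000 nM and compound 3 (`COc1cccc(Nc2nccc(-c3ccc(C)o3)n2)c1`) gives 1500 nM, two values within the usual scatter of each other. Compound 2 (`Cc1cn(-c2ccc(Nc3nccc(-c4ccncc4)n3)cc2)cn1`) is reported only as a limit, > 3000 nM. Among the three results, compound 2 alone stands at the limit of > 3000 nM in this assay, at which 1 of the 3 values shown sits. Compound 4 (`Fc1ccc(Nc2nccc(-c3ccncc3)n2)cc1`) has fluoro in place of 4-methyl-1H-imidazol-1-yl on an aromatic carbon. Going by the values given here, no measured step isolates this change, so the expectation leans only on the numbers that compound 1 and compound 3 give in this assay. The expected step, an at least 1.2-fold lower number from compound 2 to compound 4 (0.07 log units; that floor lies within the scatter), is small and toward a lower number, hardly beyond the scatter. For compound 4 the estimate is 2500 nM, with an expected range of 800 nM to 8000 nM.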

Compound 4, half-maximal inhibitory concentration: 1900 nM
For compound 4 the middle estimate is 1.3-fold (0.12 log units) above the measured one; measured number inside the range.
By their numbers in this assay, from the lowest: compounds 3, 4 and 1 (each within the scatter of the next).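

In this assay, fluoro in place of 4-methyl-1H-imidazol-1-yl, on an aromatic carbon para to a large group, gives an at least 1.5-fold lower number from compound 2 to compound 4 (0.19 log units; that floor lies within the scatter). Going by these compounds alone, this is the first step read at this position, and with fluoro there compound 4 gives a measured number, 1900 nM. From the compounds shown here alone, compound 2 remains a limit, so the true size of the step stays unknown: the limit of > 3000 nM in this assay, at which 1 of the 4 values shown sits.

The compounds shown leave open how an amine or a carboxylic acid would read at this position. They also do not tell whether the same change would give a similar step on the core of compound 1.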